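A few compounds are considered here, and "the series" means these few. Any claim that something is new, unique, unknown or untested is made for them only; others in the source may bear on it.

Compound 3 `O=C(O)/C=C/c1nc(CSc2c(Cl)cccc2Cl)ccc1OCc1ccc(F)cc1` sits at the top of the three numbers seen so far: in an assay on isolated protein for binding affinity to leukotriene B4 receptor 1 (Homo sapiens) (a lower number here means a stronger inhibitor, a higher number a weaker inhibitor), compound 3 gives 12 nM. Compound 1 `COc1ccc(CCOc2ccc(CSc3c(Cl)cccc3Cl)nc2/C=C/C(=O)O)cc1` gives 1.2 nM in this assay, and compound 2 `O=C(O)/C=C/c1nc(CSc2c(Cl)cccc2Cl)ccc1OCCc1ccc(Cl)cc1` gives 1.3 nM. The step of a 1.1-fold higher number from compound 1 to compound 2 (0.03 log units; within the scatter) shows that the two lie together. Compound 3 differs from both in the group on the saturated chain carbon bound to the oxygen on the aromatic ring, and the steps of a 10-fold higher number from compound 1 to compound 3 (1.00 log units; beyond the scatter) and a 9.2-fold higher number from compound 2 to compound 3 (0.97 log units; beyond the scatter) both go up by about the same amount.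

Compound 4 `O=C(O)/C=C/c1nc(CSc2c(Cl)cccc2Cl)ccc1OCCCc1ccccc1` has not yet been measured. It carries phenethyl in place of 4-fluorophenyl on a saturated chain carbon bound to an oxygen on an aromatic ring; read one bond further out, the change is 4-fluorobenzyl to 3-phenylpropyl. The two measured steps that bear on this place both moved from a two-carbon link to a one-carbon link and raised the number. Compound 4 goes the other way, to a link longer than in compound 1 or compound 2, and with no substituent on the ring. A step back toward the lower numbers is therefore expected, though its size is uncertain. Compound 4 is estimated at 3 nM, within 1 nM to 12 nM, meaning an expected step of a 4.0-fold lower number from compound 3 to compound 4 (0.60 log units; beyond the scatter).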

Compound 4, inhibition constant: 1.4 nM
Compound 4: middle estimate off by 2.1-fold (0.33 log units), on the high side; low and high end bracket the measured number.
By their numbers in this assay, from the lowest: compounds 1, 2 and 4 (each within the scatter of the next); then compound 3.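

The change from 4-fluorobenzyl to 3-phenylpropyl gives an 8.6-fold lower number from compound 3 to compound 4 (0.93 log units; beyond the scatter) in this assay, so the rise seen with compound 3 is not a lasting feature of this position and can be undone by a change at this same place. The new group also needs no substituent on its ring to match the other two compounds: a 1.1-fold higher number from compound 2 to compound 4 (0.03 log units; within the scatter) and a 1.2-fold higher number from compound 1 to compound 4 (0.07 log units; within the scatter) both lie within the scatter, so the chloro and methoxy groups of those compounds show no advantage over the unsubstituted ring of compound 4. Of the four compounds, only compound 3 stands apart, yet the step to compound 4 changes both the chain and the fluorine, so this single step cannot say which of the two matters.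

The compounds shown leave open whether an unsubstituted benzyl group would give a number like that of compound 3 or like that of compound 4, and whether a longer chain such as 4-phenylbutyl would hold the number. They also leave open whether an amine or a carboxylic acid on this ring would be tolerated.

No outside evidence bears on why these numbers fall as they do.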